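Swapping the amide aryl for a cyclohexenyl ring

The compounds below may be only part of what the source reports. "The series", "measured", "known", "first", "only" and "open" are said of these compounds alone.

Compound 1 `COc1cccc(C(=O)Nc2cc(-c3ccccc3)nn2-c2ccccc2)c1`: 102 nM
Compound 2 `O=C(Nc1cc(-c2ccccc2)nn1-c1ccccc1Br)c1ccccc1`: 200 nM

In a functional assay on cells for positive allosteric modulation of metabotropic glutamate receptor 5 (Rattus norvegicus), read by calcium flux (on this read-out lower numbers stand for an effect already at smaller amounts and higher numbers for an effect only at larger amounts of compound), compound 1 gives 102 nM, while compound 2 gives 200 nM. Compound 1 has the smaller of the two numbers, but the gap to compound 2 lies within the scatter, so the two are not separated. For the measured compounds named here, no step between measured compounds is available. Compound 3 `O=C(Nc1cc(-c2ccccc2)nn1-c1ccccc1)C1=CCCCC1` differs from compound 1 by cyclohex-1-en-1-yl in place of 3-methoxyphenyl on a carbonyl carbon. Going by the values given here, with no measured step of this kind, compound 3 is estimated at 250 nM, within 80 nM to 800 nM, which means an expected modest rise a 2.5-fold higher number from compound 1 to compound 3 (0.39 log units; beyond the scatter) that may still fall within the scatter.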

Compound 3, half-maximal effective concentration: 3300 nM
Beside the measured number, compound 3's estimate is 13-fold (1.12 log units) below it; the whole stated range lies below it.
By their numbers in this assay, from the lowest: compounds 1 and 2 (each within the scatter of the next); then compound 3.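

In this assay, the group on the carbonyl carbon whose other neighbour is the amide-type nitrogen proves far from interchangeable: cyclohex-1-en-1-yl in place of 3-methoxyphenyl gives a 32-fold higher number from compound 1 to compound 3 (1.51 log units; beyond the scatter) in a single change. The earlier compounds shown here, with no step between them, could not show that this position responds so strongly to a change of ring.

The compounds shown leave open whether a saturated cyclohexyl or a pyridyl ring here would keep the lower number, or whether the oxygen of the methoxy group matters on its own. No measurement at hand accounts for the size of this step.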